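Compound 1 to compound 3: propyl to sec-butyl

The source may report more compounds than this note shows. Statements on the series, on what has been measured and on what is new or still open speak of the compounds shown alone.

Measured in a functional assay on the whole organism with Mus musculus as the target; a lower number here means that less compound is needed, a higher number that more compound is needed for the effect:
- compound 1 `CCC[C@H]1C(=O)N=C(N)N1C(=O)OCc1ccccc1` gives 141 mg/kg
- compound 2 `CCC[C@@H]1C(=O)N=C(N)N1C(=O)OCc1ccccc1` gives 374 mg/kg

Compound 1 holds the lower of the two numbers. Compound 3 `CCC(C)[C@H]1C(=O)N=C(N)N1C(=O)OCc1ccccc1` differs from it by methyl in place of hydrogen on a saturated chain carbon bound to a saturated chain carbon and a saturated ring carbon, which turns propyl into sec-butyl. Going by the values given here, only one measured step bears on this, and only indirectly: a 2.7-fold higher number from compound 1 to compound 2 (0.42 log units; beyond the scatter). It changes configuration alone and says nothing of an added methyl. With that modest size as a guide, no step beyond the scatter is expected in this assay, and no direction is favoured. The expected step is a 1.1-fold higher number from compound 1 to compound 3 (0.03 log units; within the scatter). For compound 3 the estimate is 150 mg/kg, with an expected range of 60 mg/kg to 380 mg/kg.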

Compound 3, dose for half-maximal effect: 176 mg/kg
The estimate for compound 3 lay 1.2-fold (0.07 log units) below the measured number; the measured number falls inside the stated range.
By their numbers in this assay, from the lowest: compounds 1 and 3 (each within the scatter of the next); then compound 2.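

Methyl in place of hydrogen, which turns propyl into sec-butyl, gives in this assay a 1.2-fold higher number from compound 1 to compound 3 (0.10 log units; within the scatter). Going by these compounds alone, the saturated chain carbon bound to the saturated ring carbon thus takes this added methyl without a step beyond the scatter, whereas the only earlier step, a 2.7-fold higher number from compound 1 to compound 2 (0.42 log units; beyond the scatter), changed configuration alone. No measured evidence bears on why the added methyl leaves the number within the scatter. Open, on these data alone, is whether a longer chain, an amine or a carboxylic acid at this position would also stay within the scatter. Also open, as far as these compounds go, is whether the configuration step seen with propyl carries over to sec-butyl.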